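A larger group on a compound at the limit

The compounds below may be only part of what the source reports. "The series", "measured", "known", "first", "only" and "open" are said of these compounds alone.

Compound 1 `N#Cc1ncc2nc1OCC/C=C\COc1ccc(O)cc1NC(=O)N2` gives > 10000 nM as a limit
Compound 2 `N#Cc1ncc2nc1OCC/C=C\COc1ccccc1NC(=O)N2` gives > 10000 nM as a limit
Compound 3 `Cc1ccc2c(c1)NC(=O)Nc1cnc(C#N)c(n1)OCC/C=C\CO2` gives > 10000 nM as a limit

In a functional assay on NCI-H1299 cells (Homo sapiens), read by flow cytometry (on this read-out higher numbers stand for an effect only at larger amounts of compound and lower numbers for an effect already at smaller amounts), compound 3 gives > 10000 nM and this is a limit, not a number. It has no position of its own among the three compounds, since the limit of > 10000 nM in this assay, at which 3 of the 3 values shown sit, describes all of them.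

The next compound, compound 4 `N#Cc1ncc2nc1OCC/C=C\COc1ccc(CCCOC3CCCCO3)cc1NC(=O)N2`, differs from compound 3 at its methyl group, and 2-((oxan-2-yl)oxy)ethyl in place of hydrogen on a saturated chain carbon bound to an aromatic carbon is the change. Cut one bond further out, the same difference reads methyl to 3-((oxan-2-yl)oxy)propyl.

Three measured steps change a group on an aromatic carbon and so come closest to this one. They are a step that the two limits leave unreadable from compound 2 to compound 3, then a step that the two limits leave unreadable from compound 1 to compound 3, and finally a step that the two limits leave unreadable from compound 1 to compound 2 as the third. None of them has a readable size, so they offer no size or direction to carry over to the new group. Nothing measured shows that any group in this set moves a compound off the limit. The likeliest result is therefore another limit, with no step beyond the usual scatter expected.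

The expected step is a number no higher from compound 3 to compound 4 (the limit leaves the size open) and it cannot be sized more closely. For compound 4 the estimated value is 10000 nM with an expected range from 2500 nM to 30000 nM in this read-out.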

Compound 4, half-maximal effective concentration: > 10000 nM
Compound 4 ended at the assay's limit; the forecaster's own chance of this, stated with the estimate: 70%; the middle value sits exactly at the limit.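

In this assay compound 4 gives > 10000 nM as a limit, not a number. Among the compounds shown here, no step from compound 1, compound 2 or compound 3 to compound 4 can be read, because all four sit at the same limit: the limit of > 10000 nM in this assay, at which 4 of the 4 values shown sit. The compounds shown leave open whether any group moves this series off the limit in this assay and how large such a step would be.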